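Chromene series, tracheal potency: from compound 3 to compound 4

The compounds below may be only part of what the source reports. "The series", "measured", "known", "first", "only" and "open" are said of these compounds alone.

Measured so far:
compound 1 `Cc1ccccc1C(=O)c1ccc2c(c1)C(n1ccccc1=O)=CC(C)(C)O2` — 6.25
compound 2 `CC1(C)C=C(n2ccccc2=O)c2cc(O)ccc2O1` — 5.31
compound 3 `CC(=O)Oc1ccc2c(c1)C(n1ccccc1=O)=CC(C)(C)O2` — 4.97

In a functional assay (trachea) with Rattus norvegicus as the target (a higher number here means a more potent compound, by a factor of ten per unit of this negative logarithm, a lower number a less potent compound), compound 3 gives 4.97, the lowest of the three numbers. Compound 2 stands nearest above it and compound 1 furthest above it; both gaps, a number 0.34 log units lower from compound 2 to compound 3 (beyond the scatter) and a number 1.28 log units lower from compound 1 to compound 3 (beyond the scatter), lie beyond the scatter.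

Compound 4 `CC1(C)C=C(n2ccccc2=O)c2cc(C#N)ccc2O1` has not yet been measured. The change from compound 3 is cyano in place of acetoxy on an aromatic carbon.

Going by the values given here, no measured step introduces a cyano group anywhere, so no step bears directly on this change. The steps that alter the same aromatic carbon are a number 0.94 log units lower from compound 1 to compound 2 (beyond the scatter), a number 1.28 log units lower from compound 1 to compound 3 (beyond the scatter) and a number 0.34 log units lower from compound 2 to compound 3 (beyond the scatter). They show that the group on this carbon moves the number by amounts well beyond the scatter, with (2-methylphenyl)carbonyl highest, hydroxy in the middle and acetoxy lowest. Cyano is a third, untested group here, so neither direction can be ruled out; a modest step upward in this assay is expected, with a wide range to cover the uncertainty.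

Compound 4 is estimated at 5.4, within 4.7 to 6.2. The expected step is a number 0.43 log units higher from compound 3 to compound 4 (beyond the scatter).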

Compound 4, logarithm of the reciprocal of the active concentration, log(1/C): 7.1
Compound 4: the middle estimate sits 1.70 log units below what was measured; measured number above the stated range.
By their numbers in this assay, from the lowest: compound 3; then compound 2; then compound 1; then compound 4.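

Cyano on this aromatic carbon gives the highest number of the four in this assay, and it stands clear of every other group shown there: a number 2.13 log units higher from compound 3 to compound 4 (beyond the scatter), a number 1.79 log units higher from compound 2 to compound 4 (beyond the scatter) and a number 0.85 log units higher from compound 1 to compound 4 (beyond the scatter). The earlier compounds shown here had (2-methylphenyl)carbonyl at the top, but compound 4 shows that a group of 2 heavy atoms can pass it on this carbon, and heavy-atom count does not order the series, as acetoxy, with 4 heavy atoms, stays lowest while the larger (2-methylphenyl)carbonyl ranks second. Nothing in the available data accounts for this ordering.

From the compounds shown here alone, how an amine, a carboxylic acid or a nitro group on this same aromatic carbon would compare with cyano remains open, so it cannot yet be said whether compound 4 marks an isolated high point or part of a wider trend. Also open, going by these compounds, is whether cyano keeps its lead once the shared core changes elsewhere, as all four compounds carry that core and all the numbers here come from this assay.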